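This account rests on a few compounds, and the source may have more. Where it says the series, first, only, none or still open, it means among the compounds named here.

Measured in a functional assay (Mus musculus) for cytotoxicity; a lower number here means that less compound is tolerated, a higher number that more compound is tolerated:
- Compound 1 `O=C(NNC(=O)c1ccc([N+](=O)[O-])o1)c1ccc2ccccc2c1`: 32000 nM
- Compound 2 `N[C@@H](C(=O)NNC(=O)c1ccc([N+](=O)[O-])o1)c1ccccc1`: 32000 nM

In this assay, compound 1 stands level with compound 2, both within the scatter of each other. Compound 3 `CC(C)(C)OC(=O)Nc1ccc2cc(C(=O)NNC(=O)c3ccc([N+](=O)[O-])o3)ccc2c1` has (tert-butoxycarbonyl)amino in place of hydrogen on an aromatic carbon of the core of compound 1 ((tert-butoxycarbonyl)amino in place of hydrogen on an aromatic carbon). Going by the values given here, no step for such a change has been measured, and the two values give no ground for expecting a large one. In this assay, the expected result is a 1.5-fold lower number from compound 1 to compound 3 (0.16 log units; within the scatter), a slight downward lean that stays within the scatter. For compound 3 the estimate is 22000 nM, with an expected range of 7000 nM to 45000 nM.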

Compound 3, half-maximal cytotoxic concentration: 32000 nM
For compound 3 the middle estimate is 1.5-fold (0.16 log units) below the measured one; measured number inside the range.
By their numbers in this assay, from the lowest: compounds 1, 2 and 3 (each within the scatter of the next).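

In this assay the step of no change at the digits printed from compound 1 to compound 3 (within the scatter) shows that (tert-butoxycarbonyl)amino can replace hydrogen on this aromatic carbon, meta to a fused ring and para to a fused ring, without a change beyond the scatter. Going by these compounds alone, the earlier compounds held no step at this position, so this is the first reading of a substituent there. Nothing measured on hand accounts for this result. Going by these compounds, whether a free amine or a smaller methoxy group at this position would read the same remains open, as do the other aromatic carbons of the shared core.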